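Aryl and benzyl thioethers on the shared core

The source may hold more compounds than are shown below. What is called first, only, known or untested is meant among the compounds shown, and "the series" means these compounds.

Compound 1 `Cc1cc(=O)oc2cc(Sc3cccc(Cl)[n+]3[O-])ccc12`: in a functional assay on KB cells (Homo sapiens) for antiproliferative activity, read by sulforhodamine B assay, with a stated time of 72 h (on this read-out lower numbers stand for stronger inhibition of growth and higher numbers for weaker inhibition of growth), compound 1 gives > 31200 nM, which is a limit of the assay rather than a number.
Compound 2 `Cc1cc(=O)oc2cc(Sc3cccc(Cl)n3)ccc12`: compound 2 gives 920 nM.
Compound 3 `Cc1cc(=O)oc2cc(SCc3cccc(C(F)(F)F)c3)ccc12`: compound 3 gives > 28500 nM, again a limit and not a number.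
Compound 4 `Cc1cc(=O)oc2cc(SCc3cccc(OC(F)(F)F)c3)ccc12`: not yet measured.

Compound 3 therefore stands at a limit, the one recorded as the limit of > 28500 nM in this assay, at which 1 of the 3 values shown sits. Compound 1 stands at the other limit, (the limit of > 31200 nM in this assay, at which 1 of the 3 values shown sits). For the measured compounds named here, only compound 2 carries a measured number, so no step between measured compounds can be sized here; of compounds 2 and 3 one can say only that one shows a number and the other a limit.

The change from compound 3 to compound 4 is trifluoromethoxy in place of trifluoromethyl on an aromatic carbon. With compound 3 already at a limit, no step beyond the usual scatter is expected in either direction; the step from compound 3 to compound 4 is estimated as a step that the limit leaves unreadable from compound 3 to compound 4. Compound 4 is expected near 30000 nM, with a range from 8000 nM to 100000 nM, and a report of only a limit is the likelier outcome.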

Compound 4, concentration for 50% growth inhibition: 14800 nM
The estimate for compound 4 lay 2.0-fold (0.31 log units) above the measured number; low and high end bracket the measured number.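

In this assay compound 4 gives 14800 nM, the only measured number among the benzyl thioethers shown. Compound 3 stands only at a limit: the limit of > 28500 nM in this assay, at which 1 of the 4 values shown sits. Trifluoromethoxy in place of trifluoromethyl on this aromatic carbon, meta to a large group, gives an at least 1.9-fold lower number from compound 3 to compound 4 (0.28 log units; that floor lies within the scatter), so the change is bounded on one side only and the floor alone does not establish a real difference at this position.

The true size of the step stays unread while compound 3 remains a limit. As far as these compounds go, it also remains open whether an amine, a carboxylic acid or a longer chain on the same aromatic carbon would give a lower number than compound 4, which would show how far this position can move growth inhibition.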